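The source may report more compounds than this note shows. Statements on the series, on what has been measured and on what is new or still open speak of the compounds shown alone.

In a functional assay on A549 cells (Homo sapiens) for antiproliferative activity, read by MTT assay, with a stated time of 48 h (on this read-out higher numbers stand for weaker inhibition and lower numbers for stronger inhibition), compound 1 `Cc1ccc(C(=O)/C=C/c2cccc(Br)c2Oc2c([N+](=O)[O-])cc(C(F)(F)F)cc2[N+](=O)[O-])cc1` gives 6.85 ug/mL and compound 2 `COc1ccc(C(=O)/C=C/c2cccc(Br)c2Oc2c([N+](=O)[O-])cc(C(F)(F)F)cc2[N+](=O)[O-])cc1` gives 12.7 ug/mL. Compound 3 `O=C(/C=C/c1cc(Br)cc(Br)c1Oc1c([N+](=O)[O-])cc(C(F)(F)F)cc1[N+](=O)[O-])c1ccc(F)cc1` has the highest number of the three, at 120 ug/mL. Compound 4 `O=C(/C=C/c1cccc(Br)c1Oc1c([N+](=O)[O-])cc(C(F)(F)F)cc1[N+](=O)[O-])c1ccc(F)cc1` departs from compound 3 by hydrogen in place of bromo on an aromatic carbon. For the measured compounds named here, no measured step shows this exchange directly. Going by the values given here, the only step available, a 1.9-fold higher number from compound 1 to compound 2 (0.27 log units; within the scatter), is methoxy in place of methyl, and it bears only indirectly: compound 1 and compound 2 both have hydrogen at this place, but they also lack the fluoro group. A large drop in this assay is therefore expected, to near their values. The expected change is a 10-fold lower number from compound 3 to compound 4 (1.00 log units; beyond the scatter). For compound 4 the estimated value is 12 ug/mL, within an expected range of 4 ug/mL to 40 ug/mL.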

Compound 4, half-maximal inhibitory concentration: 26.3 ug/mL
Compound 4: the middle estimate sits 2.2-fold (0.34 log units) below what was measured; the measured number falls inside the stated range.
By their numbers in this assay, from the lowest: compounds 1 and 2 (each within the scatter of the next); then compound 4; then compound 3.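

In this assay, for the compounds shown here, the exchange of hydrogen for bromo at this place gives a 4.6-fold lower number from compound 3 to compound 4 (0.66 log units; beyond the scatter) and is the first direct reading of this change, with the fluoro group held fixed. With that bromo group gone, fluoro in place of methoxy gives a 2.1-fold higher number from compound 2 to compound 4 (0.32 log units; beyond the scatter) and fluoro in place of methyl gives a 3.8-fold higher number from compound 1 to compound 4 (0.58 log units; beyond the scatter) so the step at the bromo place is not the only one beyond the scatter. Nothing at hand explains these differences. The compounds shown leave open how chloro or an amine would read at this place. They also leave open whether the same exchange reads alike with methyl or methoxy in place of fluoro.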